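A Pyrazole Replaces the Benzimidazole in a Thiazole Series

This account rests on a few compounds, and the source may have more. Where it says the series, first, only, none or still open, it means among the compounds named here.

Measured compounds:
compound 1, `O=C(Cn1cnc2cccnc21)N1CCN(c2ncccc2-c2nc3ccccc3[nH]2)CC1`, 496 nM
compound 2, `CCOc1ncc(-c2nc(C(F)(F)F)sc2N2CCN(C(=O)Cn3cnc4ccccc43)[C@H](C)C2)cn1`, 2 nM

The two measured compounds were tested in a functional assay on CHO-K1 cells for antagonist activity at C-X-C chemokine receptor type 3 (Homo sapiens), read by FLIPR, with a stated time of 10 min; a lower number here means a stronger inhibitor, a higher number a weaker inhibitor. Compound 1 gives 496 nM there, while compound 2 gives 2 nM, the lowest number of the two. Compound 1 is the nearest comparison to compound 2, and its value lies well beyond the scatter of the method. Going by the values given here, these two compounds differ in many places at once, so no single step between them can be read off, and only the two numbers themselves are known.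

Compound 3, `CCOc1ncc(-c2nc(C(F)(F)F)sc2N2CCN(C(=O)Cn3ccc(C(F)(F)F)n3)[C@H](C)C2)cn1`, has not yet been measured. It keeps the core of compound 2 and differs from it in one place: 3-(trifluoromethyl)-1H-pyrazol-1-yl in place of 1H-benzimidazol-1-yl on a saturated chain carbon bound to a carbonyl carbon. Among the compounds with values here, with no comparable step available, the size of this change in this assay is open. Compound 3 is expected to give a somewhat higher number than compound 2, with a step of a 3.0-fold higher number from compound 2 to compound 3 (0.48 log units; beyond the scatter) that may lie only a little beyond the scatter. Compound 3 is estimated at 6 nM, within the range from 1.5 nM to 25 nM.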

Compound 3, half-maximal inhibitory concentration: 3.8 nM
The estimate for compound 3 lay 1.6-fold (0.20 log units) above the measured number, and the stated range covers the measured number.
By their numbers in this assay, from the lowest: compounds 2 and 3 (each within the scatter of the next); then compound 1.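

At the place on a saturated chain carbon bound to a carbonyl carbon, 3-(trifluoromethyl)-1H-pyrazol-1-yl in place of 1H-benzimidazol-1-yl gives, in this assay, a 1.9-fold higher number from compound 2 to compound 3 (0.28 log units; within the scatter), so the two compounds cannot be told apart there. On this core, then, the six-membered aromatic ring of carbon only that leaves with the 1H-benzimidazol-1-yl group is not needed to keep the number at this level, and a single five-membered aromatic ring carrying a trifluoromethyl group does as well, something the many-place difference between compound 1 and compound 2 could not show. Nothing shown here accounts for this result.

On these data alone, whether the trifluoromethyl group itself matters stays open, as does how an unsubstituted 1H-pyrazol-1-yl, or a pyrazole carrying a methyl, a nitrile or an amine in its stead, would read in this assay. As far as these compounds go, it is also open whether the same exchange would hold on the core of compound 1, where the number is far higher.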